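Replacing the pyridinyl arm of compound 2: what to expect

The source may report more compounds than this note shows. Statements on the series, on what has been measured and on what is new or still open speak of the compounds shown alone.

Both measured compounds were tested in a functional assay on BMMC cells (Mus musculus, strain C57BL/6) for inhibition, with stated times of 5 days and 48 h; a higher number here means a weaker inhibitor, a lower number a stronger inhibitor:
compound 1 `C=C1CC[C@@H]2[C@](C)(CNCc3ccc(OC)c(OC)c3)[C@H](O)CC[C@@]2(C)[C@@H]1/C=C/C1=CCOC1=O` gives 3740 nM
compound 2 `C=C1CC[C@@H]2[C@](C)(CNCc3ccncc3)[C@H](O)CC[C@@]2(C)[C@@H]1/C=C/C1=CCOC1=O` gives 2030 nM

Among the compounds with values here, compound 2 holds the lower of the two numbers, and its only neighbour is compound 1; the step of a 1.8-fold lower number from compound 1 to compound 2 (0.27 log units; within the scatter) separating them lies within the scatter, so the two values cannot be ordered with confidence.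

Compound 3 `C=C1CC[C@@H]2[C@](C)(CNCc3ccc4c(c3)CC=N4)[C@H](O)CC[C@@]2(C)[C@@H]1/C=C/C1=CCOC1=O` has not yet been measured. It differs from compound 2 in a single place: a group of 9 heavy atoms (8 carbon, 1 nitrogen; one five-membered non-aromatic ring with 1 hetero atom, one six-membered aromatic ring of carbon only) in place of a group of 6 heavy atoms (5 carbon, 1 nitrogen; one six-membered aromatic ring with 1 hetero atom), on a saturated chain carbon bound to an amine nitrogen. Within the data shown here, the only measured step that touches the same place is the exchange on the saturated chain carbon bound to the amine nitrogen, a 1.8-fold lower number from compound 1 to compound 2 (0.27 log units; within the scatter), and that step did not rise above the scatter. Among the measured compounds shown here, no measured compound carries the entering group, so nothing shows how the bicyclic group itself behaves in this assay.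

The expectation for compound 3 therefore rests on compound 2 alone. In this assay compound 3 is expected to show a 1.2-fold higher number from compound 2 to compound 3 (0.09 log units; within the scatter), a step that would stay within the scatter. The estimate for compound 3 is 2500 nM, with a range from 800 nM to 8000 nM.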

Compound 3, half-maximal inhibitory concentration: 550 nM
The estimate for compound 3 lay 4.5-fold (0.66 log units) above the measured number; the measured number lies below the stated range.
By their numbers in this assay, from the lowest: compound 3; then compounds 2 and 1 (each within the scatter of the next).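

In this assay this position, the saturated chain carbon bound to an amine nitrogen, now proves able to move the number beyond the scatter: the group of 9 heavy atoms gives a 3.7-fold lower number from compound 2 to compound 3 (0.57 log units; beyond the scatter) and, against the other single-ring arm, a 6.8-fold lower number from compound 1 to compound 3 (0.83 log units; beyond the scatter) without any change elsewhere in the molecule. The two single-ring arms, pyridin-4-yl and 3,4-dimethoxyphenyl, stay within the scatter of each other, so among these three compounds only the arm with two rings, one five-membered non-aromatic and one six-membered aromatic of carbon only, stands apart from the others. Nothing available accounts for this step.

Going by these compounds, it remains open whether the step follows the second ring as such, its ring nitrogen or its double bond outside aromatic rings, a question that an all-carbon naphthalen-2-yl arm or an indol-5-yl arm could help to answer. Also open, on these data alone, is whether the lower number would survive a longer chain in place of the single saturated chain carbon, or an acetyl group on the amine nitrogen.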